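Ester variation on a nitroanilide cyclohexane core

This account rests on a few compounds, and the source may have more. Where it says the series, first, only, none or still open, it means among the compounds named here.

Compound 3 `O=C(OC1(C(=O)Nc2ccc([N+](=O)[O-])cc2)CCCCC1)c1ccc([N+](=O)[O-])cc1` gives the lowest number of the three in a functional assay on MCF7 cells (Homo sapiens) for inhibition, read by MTT assay, with a stated time of 72 h (on this read-out higher numbers stand for weaker inhibition and lower numbers for stronger inhibition), at 8.7 nM. Compound 1 `O=C(OC1(C(=O)Nc2ccc([N+](=O)[O-])cc2)CCCCC1)c1ccc(C(F)(F)F)cc1` gives 27.1 nM, and compound 2 `Cc1ccccc1C(=O)OC1(C(=O)Nc2ccc([N+](=O)[O-])cc2)CCCCC1` gives 516 nM; the steps of a 3.1-fold lower number from compound 1 to compound 3 (0.49 log units; beyond the scatter) and a 59-fold lower number from compound 2 to compound 3 (1.77 log units; beyond the scatter) both lie beyond the scatter, so compound 3 is the most potent measured compound. Compound 4 `O=C(/C=C/c1ccccc1)OC1(C(=O)Nc2ccc([N+](=O)[O-])cc2)CCCCC1` differs by 2-phenylethenyl in place of 4-nitrophenyl on a carbonyl carbon. The steps at this same carbonyl carbon bear on it: a 3.1-fold lower number from compound 1 to compound 3 (0.49 log units; beyond the scatter) and a 59-fold lower number from compound 2 to compound 3 (1.77 log units; beyond the scatter) show that exchanging the 4-nitrophenyl for another group raised the number each time. A rise beyond the scatter is therefore expected for compound 4, written as the estimated step of a 6.9-fold higher number from compound 3 to compound 4 (0.84 log units; beyond the scatter). Compound 4 is estimated at 60 nM in this assay, within 15 nM to 250 nM.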

Compound 4, half-maximal inhibitory concentration: 57.6 nM
For compound 4 the middle estimate is 1.0-fold (0.02 log units) above the measured one, and the stated range covers the measured number.
By their numbers in this assay, from the lowest: compound 3; then compound 1; then compound 4; then compound 2.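

In this assay, an aromatic ring joined to this carbonyl carbon through an ethenyl link still gives a low number, though the 4-nitrophenyl group keeps the lowest: a 6.6-fold higher number from compound 3 to compound 4 (0.82 log units; beyond the scatter). The 2-phenylethenyl group falls between the two other replacements, with a 9.0-fold lower number from compound 2 to compound 4 (0.95 log units; beyond the scatter) and a 2.1-fold higher number from compound 1 to compound 4 (0.33 log units; beyond the scatter), so a group with no nitrogen or oxygen atoms can outdo 2-methylphenyl but not 4-(trifluoromethyl)phenyl. Nothing given here explains this order. As far as these compounds go, it remains open how a saturated 2-phenylethyl chain or a 4-aminophenyl group would compare on this carbonyl carbon.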